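Allyl versus propargyl amides: toxicity notes

The source may hold more compounds than are shown below. What is called first, only, known or untested is meant among the compounds shown, and "the series" means these compounds.

Measured so far:
Compound 1, `C=CCNC(=O)/C(C)=C(\C)c1cc(OC)c(OC)c(OC)c1`, in a toxicity assay on the whole organism (strain Icem-CET (SPF Caw)) for cytotoxicity, with Mus musculus as the target (a higher number here means that more compound is needed for the effect, a lower number that less compound is needed), gives 190 mg/kg.
Compound 2, `C=CCNC(=O)/C(C)=C(/C)c1ccccc1`, in this assay gives 400 mg/kg.
Compound 3, `C#CCNC(=O)/C(C)=C(\C)c1ccc(OC)cc1`, in this assay gives 150 mg/kg.

Among these three numbers compound 1 stands second highest. Its nearest neighbour is compound 3, and the two values lie within the usual scatter of each other, so nothing can be said about an order between them. Going by the values given here, compound 2 stands furthest from compound 1 with a higher number, and that gap is beyond the scatter; no single-point step between measured compounds is available here, so the two values are simply noted side by side.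

Compound 4, `C#CCNC(=O)/C(C)=C(\C)c1cc(OC)c(OC)c(OC)c1`, is not yet measured. It differs from compound 1 by ethynyl in place of vinyl on a saturated chain carbon bound to an amide-type nitrogen; read one bond further out, this is allyl to propargyl.

Among the compounds with values here, no measured pair in this set isolates that change, so the size of the step in this assay cannot be read off. The expectation is that the step from compound 1 to compound 4 stays within the scatter, a 1.1-fold lower number from compound 1 to compound 4 (0.05 log units; within the scatter), without a clear direction. Compound 4 is accordingly estimated at 170 mg/kg, in a range from 90 mg/kg to 340 mg/kg.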

Compound 4, dose for half-maximal effect: 150 mg/kg
Beside the measured number, compound 4's estimate is 1.1-fold (0.05 log units) above it, within the range that was stated.
By their numbers in this assay, from the lowest: compounds 3, 4 and 1 (each within the scatter of the next); then compound 2.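

The exchange of vinyl for ethynyl on a saturated chain carbon bound to an amide-type nitrogen, read one bond further out as allyl to propargyl, now has a measured size in this assay: a 1.3-fold lower number from compound 1 to compound 4 (0.10 log units; within the scatter). Going by these compounds alone, on the core of compound 1, this position therefore carries either the allyl or the propargyl group with no readable difference in the dose, a point that compounds 2 and 3 could not settle, since each differs from compound 1 in more than one place and no step to either can be read. Nothing at hand accounts for this result or bears on a cause for it.

From the compounds shown here alone, this is a single pair on one core, so it remains open whether allyl to propargyl reads the same way on the cores of compound 2 or compound 3. Also open, going by these compounds, is how the dose responds when the amide nitrogen carries a saturated propyl chain, a longer chain such as hexyl, or a chain ending in an amine or a carboxylic acid.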